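Replacing a hydroxymethyl with a carboxy on the amide chain

The compounds below may be only part of what the source reports. "The series", "measured", "known", "first", "only" and "open" are said of these compounds alone.

Of the compounds shown here, three with a shared core have been measured in a functional assay on PC-3 cells (Homo sapiens) for antiproliferative activity, read by MTT assay, with a stated time of 24 h; on this read-out higher numbers stand for weaker inhibition and lower numbers for stronger inhibition. Compound 1 `CCN(CC)CCNC(=O)c1ccc(C(CC)(CC)c2ccc(OCS(=O)(=O)c3ccccc3)c(C)c2)n1CC` gives 7130 nM in this assay. Compound 2 `CCn1c(C(=O)NC2(CO)CC2)ccc1C(CC)(CC)c1ccc(OCS(=O)(=O)c2ccccc2)c(C)c1` gives 3560 nM in this assay. Compound 3 `CCn1c(C(=O)NCCCO)ccc1C(CC)(CC)c1ccc(OCS(=O)(=O)c2ccccc2)c(C)c1` gives 11300 nM in this assay, the highest of the three numbers; its nearest neighbour is compound 1, and the two lie within the scatter of each other, whereas the gap to compound 2 lies beyond it, as a 3.2-fold higher number from compound 2 to compound 3 (0.50 log units; beyond the scatter) shows. The other two steps, a 2.0-fold lower number from compound 1 to compound 2 (0.30 log units; within the scatter) and a 1.6-fold higher number from compound 1 to compound 3 (0.20 log units; within the scatter), are both within the scatter.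

Compound 4 `CCn1c(C(=O)NCCC(=O)O)ccc1C(CC)(CC)c1ccc(OCS(=O)(=O)c2ccccc2)c(C)c1` has not yet been measured in this assay. It differs from compound 3 in one place: carboxy in place of hydroxymethyl on a saturated chain carbon, two bonds along the chain from an amide-type nitrogen. Among the measured compounds shown here, no measured step involves a carboxy, so the nearest guide is the change at the same place between compound 1 and compound 3, which was within the scatter. On that basis the step from compound 3 to compound 4 is expected to stay within the scatter, with at most a slightly higher number, and compound 4 is estimated at 14000 nM in this assay, within a range of 6000 nM to 35000 nM, an expected step of a 1.2-fold higher number from compound 3 to compound 4 (0.09 log units; within the scatter).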

Compound 4, half-maximal inhibitory concentration: 14400 nM
Compound 4: middle estimate off by 1.0-fold (0.01 log units), on the low side; measured number inside the range.
By their numbers in this assay, from the lowest: compounds 2, 1, 3 and 4 (each within the scatter of the next, the first and the last beyond it).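

In this assay, the change to carboxy in place of hydroxymethyl on a saturated chain carbon, two bonds along the chain from an amide-type nitrogen, gives a 1.3-fold higher number from compound 3 to compound 4 (0.11 log units; within the scatter) and so separates the two groups by no more than repeat measurements would, which means that this first carboxy on the chain leaves the reading where the hydroxymethyl had it. The new end group does open gaps that the hydroxymethyl chain did not fully show: carboxy in place of diethylamino at the same place gives a 2.0-fold higher number from compound 1 to compound 4 (0.31 log units; beyond the scatter) and thus lies just past the scatter, where the corresponding hydroxymethyl step had stayed within it, while 2-carboxyethyl in place of 1-(hydroxymethyl)cyclopropyl on the amide-type nitrogen gives a 4.0-fold higher number from compound 2 to compound 4 (0.61 log units; beyond the scatter) as the largest step in the set so far. Nothing available explains these steps.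

Going by these compounds, what remains open is whether a longer chain carrying the carboxy, or a methyl ester or a primary amine at this same place, would read any differently from these chains. Equally open, on these data alone, is whether a carboxy set directly on the cyclopropane ring of compound 2 would keep that compound's lower number.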